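This account rests on a few compounds, and the source may have more. Where it says the series, first, only, none or still open, it means among the compounds named here.

Measured so far in a functional assay on MCF7 cells (Homo sapiens) for cytotoxicity, read by MTT assay, with a stated time of 48 h; a lower number here means a stronger inhibitor, a higher number a weaker inhibitor:

Compound 1 (`C=C/C(C)=C\CC/C(C)=C/c1cc(C(=O)O)co1`): 61900 nM
Compound 2 (`C=C/C(C)=C/CC/C(C)=C/c1cc(C(=O)O)co1`): 74500 nM

Compound 1 has the lower of the two numbers only on paper, since it lies within the scatter of compound 2 and holds no real lead. For the measured compounds named here, the one measured step (a 1.2-fold higher number from compound 1 to compound 2 (0.08 log units; within the scatter)) comes with the fact that compounds 1 and 2 differ only in the configuration as drawn and with no other difference.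

Compound 3 (`C=C/C(C)=C\CC/C(C)=C/c1cc(C(=O)OC)co1`) keeps the rest of compound 1 and alters a single group. The difference is methyl in place of hydrogen on an oxygen next to a carbonyl group and amounts to carboxy to methoxycarbonyl, with methyl in place of hydrogen on an oxygen next to a carbonyl group.

The measured step concerns a double bond and leaves this group untouched, so it gives no size or direction for the new change. With nothing measured at this group, no step beyond the scatter is expected in this assay, although the uncertainty is wide. The expected change (a 1.2-fold lower number from compound 1 to compound 3 (0.09 log units; within the scatter)) is therefore small. For compound 3 the estimated value is 50000 nM with an expected range from 18000 nM to 120000 nM in this account.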

Compound 3, half-maximal inhibitory concentration: 75400 nM
Estimate against measurement, compound 3: 1.5-fold (0.18 log units) below, and the stated range covers the measured number.
By their numbers in this assay, from the lowest: compounds 1, 2 and 3 (each within the scatter of the next).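

In this assay, for the compounds shown here, the first measured change at this group, methyl in place of hydrogen on an oxygen next to a carbonyl group, gives a 1.2-fold higher number from compound 1 to compound 3 (0.09 log units; within the scatter). Going by these compounds alone, the earlier compounds differed only at a double bond, so this is the first sign that going from carboxy to methoxycarbonyl, with the rest of compound 1 kept, leaves the read-out within the scatter: in this assay, on this one pair, the hydrogen on that oxygen can be replaced by methyl without a readable step in either direction. Nothing at hand accounts for this result, and the one known fact about these compounds concerns the configuration of a double bond rather than this group.

What the compounds shown leave open is whether a larger ester such as ethoxycarbonyl, or an amide or a nitrile in place of the carboxy group, would move the number beyond the scatter. Within the data shown here, it is also open whether the methoxycarbonyl result holds with the double bond drawn as in compound 2, since the one step at this group starts from compound 1.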